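Extending the Side Chain on a Shared Nucleoside Core

This account rests on a few compounds, and the source may have more. Where it says the series, first, only, none or still open, it means among the compounds named here.

Compound 1, `CC(C)c1cn([C@H]2C[C@@H]3OP(=O)(O)OC[C@H]3O2)c(=O)[nH]c1=O`, in a functional assay on Raji cells (Homo sapiens) (a higher number here means a weaker inhibitor, a lower number a stronger inhibitor), gives > 500 ug/mL, which is a limit of the assay and not a measured number.
Compound 2, `CCCCc1cn([C@H]2C[C@H](O)[C@@H](CO)O2)c(=O)[nH]c1=O`, in this assay gives > 500 ug/mL, again a limit of the assay.
Compound 3, `CCCc1cn([C@H]2C[C@H](O)[C@@H](CO)O2)c(=O)[nH]c1=O`, in this assay gives > 500 ug/mL, also a limit of the assay.

Compound 3 therefore stands where every measured compound stands: at the limit of > 500 ug/mL in this assay, at which 3 of the 3 values shown sit. Among the measured compounds shown here, no measured compound gives a real number, so none can be called stronger or weaker than another. For the measured compounds named here, the one step between compounds that differ in a single place, a step that the two limits leave unreadable from compound 2 to compound 3, cannot be read, since both of its ends are limits.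

Compound 4, `CCCCCCc1cn([C@H]2C[C@H](O)[C@@H](CO)O2)c(=O)[nH]c1=O`, differs from compound 3 by propyl in place of hydrogen on a saturated chain carbon, three bonds along the chain from an aromatic carbon. Going by the values given here, the only measured step that bears on this change is the one from compound 2 to compound 3, and its size is not readable. There is thus no basis to expect a step of any particular size or direction in this assay; what the data show is that two chains of different length both sit at the limit.

Compound 4 is expected to give 600 ug/mL, most likely reported again as a limit, with a range from 250 ug/mL to 3000 ug/mL. The step from compound 3 to compound 4 is estimated as a step that the limit leaves unreadable from compound 3 to compound 4.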

Compound 4, concentration for 50% inhibition: 173 ug/mL
Beside the measured number, compound 4's estimate is 3.5-fold (0.54 log units) above it, and the stated range ends above it.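

Among the compounds shown here, for the first time, a chain at this position gives a real number rather than a limit in this assay, so the effect of changing its length can be given a size. Going to the hexyl chain gives an at least 2.8-fold lower number from compound 3 to compound 4 (0.46 log units; beyond the scatter), and the same chain gives an at least 2.8-fold lower number from compound 2 to compound 4 (0.46 log units; beyond the scatter); each of these steps starts from a limit. The hexyl chain of compound 4 is the only one shown to come off the limit, while the rest of the set stays there: the limit of > 500 ug/mL in this assay, at which 3 of the 4 values shown sit.

Going by these compounds, what an octyl or decyl chain would give on the shared core remains open, as does whether a chain ending in an amine or a carboxylic acid would behave like the hexyl chain. Also open, on these data alone, is what the hexyl chain would give on the core of compound 1, which differs from compound 4 in more than one place and so cannot be compared with it directly.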